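The source may hold more compounds than are shown below. What is called first, only, known or untested is meant among the compounds shown, and "the series" means these compounds.

In a functional assay on MCF7 cells (Homo sapiens) for inhibition, read by MTT assay, with stated times of 18 h and 4 h (a lower number here means a stronger inhibitor, a higher number a weaker inhibitor), compound 3 `CCCCCCOP(=O)(O)OCCSC(=S)N1CCCCC1` gives 62000 nM, the higher of the two numbers in the series, while compound 2 `CCCCCCCCOP(=O)(O)OCCSC(=S)N1CCCCC1` gives 26000 nM. Compound 4 `CCCCCCCCCCCCCCCCOP(=O)(O)OCCSC(=S)N1CCCCC1` differs from compound 3 by decyl in place of hydrogen on a saturated chain carbon, six bonds along the chain from an oxygen on an unsaturated carbon. Among the compounds with values here, the one measured step on this chain is a 2.4-fold higher number from compound 2 to compound 3 (0.38 log units; beyond the scatter), modest and beyond the scatter; read in reverse, it suggests a lower number as the chain grows. With the long chain that compound 4 would carry, compound 1 `CCCCCCCCCCCCCCCCOP(=O)(O)OCCSC(=S)N1CCCCCC1` reads > 100000 nM, which is a limit and not a number. Only a small fall in this assay is therefore expected, possibly within the scatter, and the estimated change is a 1.4-fold lower number from compound 3 to compound 4 (0.14 log units; within the scatter). Compound 4 is estimated at 45000 nM, with an expected range of 9000 nM to 150000 nM.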

Compound 4, half-maximal inhibitory concentration: 29000 nM
Beside the measured number, compound 4's estimate is 1.6-fold (0.19 log units) above it; measured number inside the range.
By their numbers in this assay, from the lowest: compounds 2 and 4 (each within the scatter of the next); then compound 3. At a limit, above all of these: compound 1.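

In this assay, decyl in place of hydrogen on a saturated chain carbon, six bonds along the chain from an oxygen on an unsaturated carbon, gives a 2.1-fold lower number from compound 3 to compound 4 (0.33 log units; beyond the scatter), but a 1.1-fold higher number from compound 2 to compound 4 (0.05 log units; within the scatter) leaves the longer chain of compound 4 within the scatter of compound 2. With the chain held, piperidin-1-yl in place of azepan-1-yl on a thiocarbonyl carbon gives an at least 3.4-fold lower number from compound 1 to compound 4 (0.53 log units; beyond the scatter), so the ring also counts. That step rests on a limit: the limit of > 100000 nM in this assay, at which 1 of the 4 values shown sits.

Still open, as far as these compounds go, is whether an even longer chain leaves this level unchanged. Also open, from the compounds shown here alone, is how a morpholin-4-yl group would read in place of piperidin-1-yl.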